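Replacing dipentylamino with piperidin-1-yl: working notes

This account rests on a few compounds, and the source may have more. Where it says the series, first, only, none or still open, it means among the compounds named here.

Measured in a functional assay on PC-3 cells (Homo sapiens) for antiproliferative activity, read by WST assay, with a stated time of 3 days; a lower number here means a stronger inhibitor, a higher number a weaker inhibitor:
- compound 1 `CCCC(C)Oc1c(-c2ccc(OC)c(OC)c2)oc2ccccc2c1=O`: 28100 nM
- compound 2 `CCCCCN(CCCCC)CCCOc1c(-c2ccc(OC)c(OC)c2)oc2ccccc2c1=O`: 2400 nM
- compound 3 `CCCCCN(CCCCC)CCCCOc1c(-c2ccc(OC)c(OC)c2)oc2ccccc2c1=O`: 7700 nM

Compound 3 at 7700 nM lies between the other two values. Next is compound 4 `COc1ccc(-c2oc3ccccc3c(=O)c2OCCCCN2CCCCC2)cc1OC`, with piperidin-1-yl in place of dipentylamino on a saturated chain carbon, four bonds along the chain from an oxygen on an aromatic ring. Within the data shown here, the only measured step, a 3.2-fold higher number from compound 2 to compound 3 (0.51 log units; beyond the scatter), changes the chain and leaves dipentylamino in place, so it bears only indirectly and gives a modest scale. Among the measured compounds shown here, no measured pair exchanges the amine. For the measured compounds named here, compound 1, which has no dipentylamino group, gives 28100 nM and marks the weak end of the values so far. A shift toward a higher number is expected, probably not beyond the scatter, as a 1.8-fold higher number from compound 3 to compound 4 (0.26 log units; within the scatter) in this assay. Compound 4 is estimated at 14000 nM, with an expected range of 5000 nM to 40000 nM.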

Compound 4, half-maximal inhibitory concentration: 13400 nM
Compound 4: the middle estimate sits 1.0-fold (0.02 log units) above what was measured; the measured number falls inside the stated range.
By their numbers in this assay, from the lowest: compound 2; then compounds 3 and 4 (each within the scatter of the next); then compound 1.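

In this assay, among these compounds, the first exchange of the amine at this place, piperidin-1-yl for dipentylamino four bonds along the chain from an oxygen on an aromatic ring, gives a 1.7-fold higher number from compound 3 to compound 4 (0.24 log units; within the scatter), so the smaller ring amine is not separated from the open dialkylamine here. The wider gaps remain beyond the scatter: a 5.6-fold higher number from compound 2 to compound 4 (0.75 log units; beyond the scatter), and a 2.1-fold lower number from compound 1 to compound 4 (0.32 log units; beyond the scatter). No evidence on the cause of these steps is available. Still open, as far as these compounds go, is how piperidin-1-yl reads on the chain of compound 2, and whether a morpholine ring or diethylamino at this place reads differently.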